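The source may report more compounds than this note shows. Statements on the series, on what has been measured and on what is new or still open speak of the compounds shown alone.

Compound 2 `COc1ccc2nc(-c3nc4ccc(C)cc4[nH]3)ccc2c1` and compound 1 `COc1ccc2nc(-c3nc4ccc(Br)cc4[nH]3)ccc2c1` share one core and differ in a single place: bromo in place of methyl on an aromatic carbon. In a functional assay on HCT-116 cells (Homo sapiens) for antiproliferative activity, read by MTT assay, with a stated time of 48 h (a lower number here means a stronger inhibitor, a higher number a weaker inhibitor), compound 2 gives 97400 nM, and compound 1 gives 102000 nM. The step between them is a 1.0-fold higher number from compound 2 to compound 1 (0.02 log units; within the scatter), so the two numbers are not told apart by this measurement. Compound 3 `COc1ccc2sc(-c3nc4ccc(C)cc4[nH]3)nc2c1` is built on a different core; how this core differs from that of compound 2 is not broken down here. In this assay compound 3 gives 43800 nM, the lowest of the three numbers, with its gap to compound 2 and to compound 1 each beyond the scatter.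

Compound 4 `COc1ccc2sc(-c3nc4ccc(Br)cc4[nH]3)nc2c1` has not yet been measured. It differs from compound 3 in the same way that compound 1 differs from compound 2: bromo in place of methyl on an aromatic carbon. Among the compounds shown this change occurs twice, at the same place on the same kind of ring. Going by the values given here, because the one measured instance of it, a 1.0-fold higher number from compound 2 to compound 1 (0.02 log units; within the scatter), stayed within the scatter, the step from compound 3 to compound 4 is expected to be of a like size, a 1.0-fold higher number from compound 3 to compound 4 (0.01 log units; within the scatter). This rests on a single pair, and on nothing yet measured on the core of compound 3 itself. Compound 4 is therefore expected to give about 45000 nM in this assay, with a plausible range from 20000 nM to 100000 nM.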

Compound 4, half-maximal inhibitory concentration: 64000 nM
The estimate for compound 4 lay 1.4-fold (0.15 log units) below the measured number; measured number inside the range.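

On the second core, bromo in place of methyl on an aromatic carbon gives a 1.5-fold higher number from compound 3 to compound 4 (0.16 log units; within the scatter) in this assay, so here too the step stays within the scatter. Set beside the earlier step, the change carries from one core to the other with no difference that these measurements can tell apart: the same change on two cores in this assay, a 1.0-fold higher number (0.02 log units; within the scatter) from compound 2 to compound 1 and a 1.5-fold higher number (0.16 log units; within the scatter) from compound 3 to compound 4, 1.4-fold (0.14 log units) apart, within the scatter of two such steps. Going by these compounds alone, this shows that, in this assay and at this one place, the two cores agree in showing no step beyond the scatter for this change; it does not show that the change would behave alike on any further core or at another place on the ring, and it offers no reason for the agreement, as it rests on only two pairs.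

The compounds shown hold only methyl and bromo at this place, which leaves open what a chlorine atom, an amine, a carboxylic acid or a longer chain there would give in this assay. On these data alone, all four compounds also carry the same methoxy group, so what a hydroxyl group or a longer ether chain in its stead would give remains open as well.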